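A few compounds are considered here, and "the series" means these few. Any claim that something is new, unique, unknown or untested is made for them only; others in the source may bear on it.

Measured so far:
- compound 1 `COc1cc(N(Cc2ccc(F)cc2)C(=O)CSc2nc3ccccc3s2)cc(OC)c1OC`: > 80000 nM
- compound 2 `COc1ccc(CN(C(=O)CSc2nc3ccccc3s2)c2cc(OC)c(OC)c(OC)c2)cc1O`: 35 nM
- compound 3 `COc1ccc(CN(C(=O)CSc2nc3cc(Cl)ccc3s2)c2cc(OC)c(OC)c(OC)c2)cc1O`: 85 nM

From the compounds shown here alone, in a functional assay on MGC-803 cells (Homo sapiens) for antiproliferative activity, read by MTT assay, with a stated time of 48 h (a lower number here means a stronger inhibitor, a higher number a weaker inhibitor), compound 1 gives only a limit, > 80000 nM, so its true value is unknown beyond that; this matches (the limit of > 80000 nM in this assay, at which 1 of the 3 values shown sits). The step to compound 4 `COc1ccc(CN(C(=O)CSc2nc3ccccc3s2)c2cc(OC)c(OC)c(OC)c2)cc1N=[N+]=[N-]` is 3-azido-4-methoxyphenyl in place of 4-fluorophenyl on a saturated chain carbon bound to an amide-type nitrogen. The nearest measured step is an at least 2200-fold lower number from compound 1 to compound 2 (3.35 log units; beyond the scatter), where a 3-hydroxy-4-methoxyphenyl group entered on the same carbon; compound 4 instead brings a 3-azido-4-methoxyphenyl group, so it shares the methoxy-bearing portion with compound 2 but not the hydroxyl. The other measured step, a 2.4-fold higher number from compound 2 to compound 3 (0.39 log units; beyond the scatter), shows that a small change elsewhere in compound 2 costs a modest amount. Compound 4 is therefore expected to fall far below the limit of compound 1, with a step of an at least 320-fold lower number from compound 1 to compound 4 (2.50 log units; beyond the scatter), though likely not as low as compound 2 since the hydroxyl is gone. The estimate for compound 4 is 250 nM, within 40 nM to 3000 nM.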

Compound 4, half-maximal inhibitory concentration: 187 nM
Estimate against measurement, compound 4: 1.3-fold (0.13 log units) above; the measured number falls inside the stated range.
By their numbers in this assay, from the lowest: compound 2; then compound 3; then compound 4. At a limit, above all of these: compound 1.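

In this assay, azido in place of hydroxy on the aromatic carbon gives a 5.3-fold higher number from compound 2 to compound 4 (0.73 log units; beyond the scatter), so the hydroxy group gives the lower number, but the azido group keeps most of the gain made over the 4-fluorophenyl group. On the saturated chain carbon bound to the amide-type nitrogen, the change gives an at least 420-fold lower number from compound 1 to compound 4 (2.63 log units; beyond the scatter), which shows that an entering group with 0 hydrogen-bond donors can still reach a low number at this position. Compound 1 stands only at a limit, so this step is a minimum and not an exact size: the limit of > 80000 nM in this assay, at which 1 of the 4 values shown sits.

From the compounds shown here alone, whether an amine or a carboxylic acid in place of the azido group would hold this level stays open. Also open, going by these compounds, is what the methoxy group contributes on its own, apart from the group that accompanies it.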